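A Second Methyl on the Amide-Bound Phenyl Ring

A few compounds are considered here, and "the series" means these few. Any claim that something is new, unique, unknown or untested is made for them only; others in the source may bear on it.

Of the compounds shown here, two built on a shared core have been tested in a functional assay on the whole organism (Ear) for inhibition, with Mus musculus as the target, at a dose of 40 mg/kg by the oral route; on this read-out higher numbers stand for more inhibition at the one dose given (going by the name of the read-out) and lower numbers for less inhibition. Compound 1 `CC(=O)Oc1ccc(-c2ccc(F)cc2F)cc1C(=O)NCc1ccccc1` gives 34.1%. Among the compounds with values here, compound 2 `CC(=O)Oc1ccc(-c2ccc(F)cc2F)cc1C(=O)Nc1cccc(C)c1` gives 12.8%, the lower of the two numbers; the only measured step, a number 21.3 percentage points lower from compound 1 to compound 2 (beyond the scatter), comes from putting 3-methylphenyl in place of benzyl on the amide-type nitrogen. Compound 3 `CC(=O)Oc1ccc(-c2ccc(F)cc2F)cc1C(=O)Nc1cc(C)ccc1C` differs from compound 2 by methyl in place of hydrogen on an aromatic carbon, on an aromatic carbon ortho to a large group and para to a methyl group, so that 3-methylphenyl becomes 2,5-dimethylphenyl. Within the data shown here, that measured step concerns the kind of group carried by the nitrogen, not the addition of a methyl to a ring already present, so no measured step bears directly on this change. The expected result is therefore a step of a number 2.2 percentage points higher from compound 2 to compound 3 (within the scatter), not beyond the scatter. Compound 3 is estimated at 15%, with a range from 0% to 35%.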

Compound 3, a percentage reported as inhibition, in the whole organism at one dose (the size of the read-out at that dose, not a potency): 22%
Estimate against measurement, compound 3: 7 percentage points below; the range from low to high includes it.
By their numbers in this assay, from the lowest: compounds 2 and 3 (each within the scatter of the next); then compound 1.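

Placing a methyl on the aromatic carbon ortho to a large group and para to a methyl group, which turns 3-methylphenyl into 2,5-dimethylphenyl, gives a number 9.2 percentage points higher from compound 2 to compound 3 (within the scatter), so this position accepts a second methyl with no change that can be told from the scatter. With this second methyl in place, the comparison with benzyl on the amide-type nitrogen reads a number 12.1 percentage points lower from compound 1 to compound 3 (beyond the scatter), so the gap to compound 1 stays beyond the scatter. Nothing available explains either step.

The compounds shown leave open whether a chlorine atom or a methoxy group on that same aromatic carbon would read differently from methyl. They also leave open whether a methyl on the benzyl ring of compound 1 would be accepted in the same way.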